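The source may hold more compounds than are shown below. What is called first, only, known or untested is meant among the compounds shown, and "the series" means these compounds.

Of the compounds shown here, three have been measured in a functional assay on MCF7 cells (Homo sapiens) for antiproliferative activity, read by MTT assay, with a stated time of 72 h (a higher number here means a weaker inhibitor, a lower number a stronger inhibitor), and a fourth waits for its number. Compound 1 `CC(C)/C=C/C(=O)Nc1cc2c(N3CCc4ccccc43)ncnc2cc1O[C@@H]1CCOC1` gives 9880 nM in this assay. Compound 2 `CC(C)/C=C/C(=O)Nc1cc2c(N3CCCc4ccccc43)ncnc2cc1O[C@@H]1CCOC1` differs from compound 1 in a single place: 1,2,3,4-tetrahydroquinolin-1-yl in place of 2,3-dihydro-1H-indol-1-yl on an aromatic carbon. In this assay compound 2 gives 4680 nM, so that exchange brought a 2.1-fold lower number from compound 1 to compound 2 (0.32 log units; beyond the scatter). Compound 3 `COc1cc2ncnc(N3CCc4ccccc43)c2cc1NC(=O)/C=C/CN(C)C` is built on another core; how its core differs from that of compound 1 is not broken down here. In this assay compound 3 gives 3370 nM, the lowest of the three numbers, though its gap to compound 2 lies within the usual scatter and only the gap to compound 1 lies beyond it.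

Compound 4 `COc1cc2ncnc(N3CCCc4ccccc43)c2cc1NC(=O)/C=C/CN(C)C` has not yet been measured. It differs from compound 3 exactly as compound 2 differs from compound 1: 1,2,3,4-tetrahydroquinolin-1-yl in place of 2,3-dihydro-1H-indol-1-yl on an aromatic carbon. The spot where the new group sits is described in the same words for both pairs, so this is the same change carried onto a second core. Among the compounds with values here, the only guide to its effect is the single earlier pair, which is thin evidence. Because that earlier exchange gave a 2.1-fold lower number from compound 1 to compound 2 (0.32 log units; beyond the scatter), a drop of similar size is expected for compound 4, namely a 1.9-fold lower number from compound 3 to compound 4 (0.27 log units; within the scatter). In this assay compound 4 is therefore estimated at 1800 nM, with a plausible range from 700 nM to 4500 nM.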

Compound 4, half-maximal inhibitory concentration: 1770 nM
Beside the measured number, compound 4's estimate is 1.0-fold (0.01 log units) above it; measured number inside the range.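

In this assay, putting 1,2,3,4-tetrahydroquinolin-1-yl in place of 2,3-dihydro-1H-indol-1-yl on the second core gives a 1.9-fold lower number from compound 3 to compound 4 (0.28 log units; within the scatter), and this step matches the one seen on the first core: the same change on two cores in this assay, a 2.1-fold lower number (0.32 log units; beyond the scatter) from compound 1 to compound 2 and a 1.9-fold lower number (0.28 log units; within the scatter) from compound 3 to compound 4, 1.1-fold (0.04 log units) apart, within the scatter of two such steps. So, within these four compounds, the exchange carries from one core to the other with no measurable difference in its size, even though the second step, taken alone, is too small to be told apart from ordinary variation between repeated measurements. Two pairs in a single assay do not make a general rule, however: they do not show that the exchange would behave the same way on any further core or in another cell line, and they do not explain why the numbers move as they do.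

The compounds shown leave open what happens when this bicyclic group is changed further, for example to a seven-membered ring fused to the benzene ring or to an open-chain methylanilino group. They also leave open whether a fluorine or a methoxy group on the benzene ring of the 1,2,3,4-tetrahydroquinolin-1-yl group would change the numbers on either core.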